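A few compounds are considered here, and "the series" means these few. Any claim that something is new, unique, unknown or untested is made for them only; others in the source may bear on it.

Measured in a functional assay on HT-29 cells (Homo sapiens) for cytotoxicity, read by XTT assay, with a stated time of 72 h; on this read-out lower numbers stand for stronger inhibition and higher numbers for weaker inhibition:
Compound 1 `COc1ccc(Cc2cc(OC)c(OC)c(OC)c2)cc1N` gives 41 nM
Compound 2 `COc1ccc(C(O)c2ccc3ccccc3c2)c(OC)c1OC` gives > 10000 nM

Within the data shown here, compound 1 gives the only exact number so far in this assay with 41 nM as its result. Compound 2 reports > 10000 nM as a limit of the assay and not a number. These two compounds differ in more than one place, so they do not show what a single swap does.

The next compound is compound 3 `COc1ccc(Cc2cc(OC)c(OC)c(OC)c2)cc1O` with hydroxy in place of amino on an aromatic carbon, ortho to a methoxy group hydroxy in place of amino on an aromatic carbon as the whole change. Among the measured compounds shown here, no measured pair shows this swap, so the expectation starts from compound 1 at 41 nM and assumes no change beyond the scatter in this assay for now. The expected 1.0-fold lower number from compound 1 to compound 3 (0.01 log units; within the scatter) is therefore small. Compound 3 is estimated at 40 nM with an expected range from 10 nM to 200 nM in this test.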

Compound 3, half-maximal inhibitory concentration: 440 nM
Estimate against measurement, compound 3: 11-fold (1.04 log units) below; the whole stated range lies below it.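

On the core of compound 1, this position is sensitive to a swap between two small groups: in this assay, hydroxy in place of amino brings an 11-fold higher number from compound 1 to compound 3 (1.03 log units; beyond the scatter) and so weaker inhibition. The two groups match in heavy-atom count, hydrogen-bond donors, hydrogen-bond acceptors and net charge, so these counts alone do not settle the outcome at this place, ortho to a methoxy group. Nothing in the data shown explains why the swap has an effect of this size.

On these data alone, it remains open whether a methylamino group, a fluorine atom or an acetamide here would stay close to compound 1 at 41 nM. As far as these compounds go, it is also open whether the swap acts alike on another core, since compound 2 differs from these compounds in more than one place.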